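Four Compounds, One Cytotoxicity Read-Out, One Open Step

The source may report more compounds than this note shows. Statements on the series, on what has been measured and on what is new or still open speak of the compounds shown alone.

Compound 1 `COc1cc(-c2cc(COCc3cn(Cc4cc(-c5ccccc5)cnc4Cl)nn3)on2)cc(OC)c1OC` gives 68500 nM
Compound 2 `COc1cc(C2=NOC(COCc3cn(Cc4cc(C)cnc4Cl)nn3)C2)cc(OC)c1OC` gives 85500 nM
Compound 3 `COc1cc(COCc2cn(Cc3cc(-c4ccccc4)cnc3Cl)nn2)cc(OC)c1OC` gives 86700 nM

All three compounds were tested in a functional assay on MCF7 cells (Homo sapiens) for cytotoxicity, read by MTT assay, with a stated time of 48 h (on this read-out lower numbers stand for stronger inhibition and higher numbers for weaker inhibition), and their values lie within the scatter of one another. Compound 2 (85500 nM) therefore stands level with both compound 1 and compound 3, and the numbers do not separate the three.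

The next step leads from compound 2 to compound 4 `COc1cc(C2=NOC(COCc3cn(Cc4cc(-c5ccc(C)cc5)cnc4Cl)nn3)C2)cc(OC)c1OC`, which has not yet been measured. The change is 4-methylphenyl in place of methyl on an aromatic carbon and amounts to 4-methylphenyl in place of methyl on an aromatic carbon. Going by the values given here, no pair of measured compounds isolates this change, so its size cannot be read directly from the data. With so little spread among the three values, no step beyond the scatter is expected in this assay, in either direction. The estimated step is a 1.1-fold lower number from compound 2 to compound 4 (0.06 log units; within the scatter) and it should stay within the scatter. For compound 4 the expected value is 75000 nM with an estimated range from 30000 nM to 150000 nM in this account.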

Compound 4, half-maximal inhibitory concentration: 12900 nM
Beside the measured number, compound 4's estimate is 5.8-fold (0.76 log units) above it, and the stated range ends above it.
By their numbers in this assay, from the lowest: compound 4; then compounds 1, 2 and 3 (each within the scatter of the next).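

Until now, the compounds shown offered no measured step, and their values in this assay could not be told apart. Going by these compounds alone, this result shows that the aromatic carbon para to a chloro group can shift the read-out: 4-methylphenyl in place of methyl gives a 6.6-fold lower number from compound 2 to compound 4 (0.82 log units; beyond the scatter), the only change between the two structures, and it adds one six-membered aromatic ring of carbon only, with 0 hydrogen-bond donors and 0 hydrogen-bond acceptors. No measurement on hand bears on the reason for this step.

The compounds shown leave open how much of the step belongs to the ring itself and how much to its methyl group, as no plain phenyl stands at this place on the core of compound 2. As far as these compounds go, it also remains open how the read-out would respond to a ring carrying an amine or a carboxylic acid here.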